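The compounds below may be only part of what the source reports. "The series", "measured", "known", "first", "only" and "open" are said of these compounds alone.

Compound 1, `N=C(S)CCCCCCN1N=C(c2ccccc2)CCC1=O`: 58.8 mg/kg
Compound 2, `CC1=NN(CCC(=N)S)C(=O)CC1`: > 100 mg/kg
Compound 3, `CN(C)C(=S)CCCCCn1nc(-c2ccccc2)ccc1=O`: 100 mg/kg

Three compounds share a core in which a thioamide-bearing chain hangs from a ring nitrogen. In a functional assay on the whole organism (stomach) with Rattus norvegicus as the target (on this read-out higher numbers stand for an effect only at larger amounts of compound and lower numbers for an effect already at smaller amounts), compound 1 gives 58.8 mg/kg, and in this assay compound 3 gives 100 mg/kg. Compound 2 stands apart: in this assay compound 2 reaches only a limit of the assay, > 100 mg/kg, so no number is known for it, only that it lies beyond the range tested. Among the measured compounds shown here, this is the point marked by the limit of > 100 mg/kg in this assay, at which 1 of the 3 values shown sits, and it leaves compound 2 as the one member of the set without a measured value.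

Compound 4, `N=C(S)CCN1N=C(c2ccccc2)CCC1=O`, has not yet been measured. It differs from compound 2 in one place, (phenyl in place of methyl on a carbon with a double bond to nitrogen), and is otherwise the same molecule with its short chain. In this assay the step from compound 2 to compound 4 is expected to move toward smaller doses, since the two compounds that carry the phenyl group, compound 1 at 58.8 mg/kg and compound 3 at 100 mg/kg, both give numbers within the assay range. The expected shift is an at least 1.4-fold lower number from compound 2 to compound 4 (0.15 log units; that floor lies within the scatter). Compound 4 is therefore estimated at 70 mg/kg, with a range from 30 mg/kg to 160 mg/kg.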

Compound 4, dose for half-maximal effect: > 100 mg/kg
Compound 4: only a limit was reported; the forecaster's own chance of this, stated with the estimate: 30%; at least 1.4-fold (0.15 log units) between middle value and limit.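

In this assay compound 4 gives > 100 mg/kg, which is a limit of the assay and not a number, so phenyl on the carbon with a double bond to nitrogen does not by itself bring the short-chain compound into the measured range. Among the compounds shown here, the step from methyl to phenyl cannot be read, since both of its ends are limits: the limit of > 100 mg/kg in this assay, at which 2 of the 4 values shown sit. The one step that can be read concerns the chain and not the phenyl: the group of 3 heavy atoms in place of the group of 7 heavy atoms gives an at least 1.7-fold higher number from compound 1 to compound 4 (0.23 log units; that floor lies within the scatter), so this floor alone does not establish a difference beyond the usual scatter.

As far as these compounds go, how far past the limit compound 2 and compound 4 lie stays open, and so does whether phenyl and methyl would differ at all on the longer chain of compound 1. The compounds shown also do not tell how an amine or a carboxylic acid in place of the thioamide would read in this assay.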